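Cytotoxicity notes on a sulfonyl-piperazine replacement

The source may hold more compounds than are shown below. What is called first, only, known or untested is meant among the compounds shown, and "the series" means these compounds.

Compound 1 `Cc1cc(/C=C/C#N)cc(C)c1Oc1nc(Nc2ccc(N3CCCC(NS(N)(=O)=O)C3)cc2)nc2ccsc12` is assessed in an ADME assay on MT4 cells (Homo sapiens) for cytotoxicity, read by MTT assay, with a stated time of 5 days; a lower number here means that less compound is tolerated, a higher number that more compound is tolerated. In this assay compound 1 gives > 217000 nM, which is a limit of the assay and not a number. Compound 2 `Cc1cc(/C=C/C#N)cc(C)c1Oc1nc(Nc2ccc(N3CCCC(NS(N)(=O)=O)C3)cc2)nc2sccc12` is the other measured member of the series. In this assay compound 2 gives > 217000 nM, again a limit rather than a number. For the measured compounds named here, compound 1 thus stands at the limit, as does the only other value shown: the limit of > 217000 nM in this assay, at which 2 of the 2 values shown sit. Going by the values given here, no step between measured compounds differing in a single place is available. Compound 3 `Cc1cc(/C=C/C#N)cc(C)c1Oc1nc(Nc2ccc(N3CCN(S(C)(=O)=O)CC3)cc2)nc2ccsc12` carries the change (4-(methylsulfonyl)piperazin-1-yl in place of 3-(sulfamoylamino)piperidin-1-yl on an aromatic carbon), that is 4-(methylsulfonyl)piperazin-1-yl in place of 3-(sulfamoylamino)piperidin-1-yl on an aromatic carbon, para to a large group. For compound 3 no movement beyond the scatter is expected in this assay, and a reading at the limit is again the likeliest outcome. The expected step of a number no higher from compound 1 to compound 3 (the limit leaves the size open) is therefore essentially none. Compound 3 is estimated at 217000 nM, within 90000 nM to 500000 nM.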

Compound 3, half-maximal cytotoxic concentration: 11500 nM
Compound 3: the middle estimate sits 19-fold (1.28 log units) above what was measured; measured number outside the range, below it.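

In this assay the place on an aromatic carbon, para to a large group, turns out to matter: 4-(methylsulfonyl)piperazin-1-yl in place of 3-(sulfamoylamino)piperidin-1-yl gives an at least 18-fold lower number from compound 1 to compound 3 (1.27 log units; beyond the scatter) as the step. As far as these compounds go, compound 1 gives > 217000 nM and that is a limit of the assay, not a number, so the true size of the step stays open. Compound 3 is the only compound shown with a number rather than a limit, and the ceiling no longer describes the whole series: the limit of > 217000 nM in this assay, at which 2 of the 3 values shown sit.

The change swaps the ring, the sulfonyl attachment and the hydrogen-bond donors together, so the compounds shown do not separate which of these goes with the step. A piperazine carrying an acetyl group or a free amine would help to separate them, as would the same 4-(methylsulfonyl)piperazin-1-yl on the core of compound 2.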